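Moving the methyl on the aryl ring of compound 1

The source may report more compounds than this note shows. Statements on the series, on what has been measured and on what is new or still open speak of the compounds shown alone.

In a functional assay on a cell-free system (Platelet, plasma, Oryctolagus cuniculus) for inhibition, with stated times of 5 min and 6 min (a lower number here means a stronger inhibitor, a higher number a weaker inhibitor), compound 1 `CCCN1C(=O)COc2cc(CNc3ccccc3C)ccc21` gives 18800 nM. For the measured compounds named here, its only measured neighbour, compound 2 `CCCCN1C(=O)COc2cc(CNc3ccccc3C)ccc21`, gives 18800 nM, which leaves compound 1 level with it.

Compound 3 `CCCN1C(=O)COc2cc(CNc3ccc(C)cc3)ccc21` keeps the core of compound 1 and differs only in the group on the amine: 4-methylphenyl in place of 2-methylphenyl on an amine nitrogen. This places 4-methylphenyl in place of 2-methylphenyl on an amine nitrogen, so the two compounds have the same atoms, joined differently.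

Going by the values given here, only one measured step is available, no change at the digits printed from compound 1 to compound 2 (within the scatter). It puts methyl in place of hydrogen on a saturated chain carbon, three bonds along the chain from an amide-type nitrogen in a ring. That step lies within the scatter, but it concerns another place in the molecule, so it bears on the new change only indirectly. Among the compounds with values here, no measured pair varies the group on the amine, and the data therefore support no direction. No step beyond the scatter is expected, though with wide uncertainty.

The expected change is a 1.0-fold lower number from compound 1 to compound 3 (0.02 log units; within the scatter). For compound 3 the estimated value is 18000 nM, within an expected range of 6000 nM to 50000 nM.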

Compound 3, half-maximal inhibitory concentration: 14200 nM
Compound 3: middle estimate off by 1.3-fold (0.10 log units), on the high side, and the stated range covers the measured number.
By their numbers in this assay, from the lowest: compounds 3, 1 and 2 (each within the scatter of the next).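

For the compounds shown here, the step gives the first measured comparison at the group on the amine. In this assay, 4-methylphenyl in place of 2-methylphenyl on an amine nitrogen gives a 1.3-fold lower number from compound 1 to compound 3 (0.12 log units; within the scatter), so moving the methyl leaves the two compounds indistinguishable in this read-out, even though this change acts on the aryl group rather than on the chain varied in the earlier pair. No measurement shown here offers an explanation for this result.

The compounds shown leave open whether the group on the amine matters at all in this assay, since both groups compared are methylphenyl and share the same atoms; a plain phenyl, a chlorophenyl or a carboxylic acid on the aryl ring could test this more widely. As far as these compounds go, it also remains open whether 4-methylphenyl would behave the same way when paired with the butyl chain of compound 2, because the two places in the molecule have so far been varied only one at a time.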